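Swapping the Amide Partner of Compound 2

This account rests on a few compounds, and the source may have more. Where it says the series, first, only, none or still open, it means among the compounds named here.

Going by the values given here, compound 2 `COc1ccc(Cl)cc1N(CC(=O)N1CCCCC1)S(=O)(=O)c1ccccc1` is the only compound here with a measured number: in a functional assay on SH-SY5Y cells (Homo sapiens), read by MTT assay, with a stated time of 24 h (on this read-out lower numbers stand for an effect already at smaller amounts and higher numbers for an effect only at larger amounts of compound), compound 2 gives 14500 nM. Compound 1 `COc1ccc(NC(=O)CN(c2cc(Cl)ccc2OC)S(=O)(=O)c2ccccc2)cc1OC` reaches only the limit of this assay, in which compound 1 gives > 20000 nM. Among the compounds with values here, the one measured step, an at least 1.3-fold lower number from compound 1 to compound 2 (0.13 log units; that floor lies within the scatter), is the single comparison that bears on the change ahead, and it is small. Compound 3 `COc1ccc(Cl)cc1N(CC(=O)Nc1ccccc1)S(=O)(=O)c1ccccc1` carries anilino in place of piperidin-1-yl on a carbonyl carbon, moving back toward an aryl amide. Guided only by the step of an at least 1.3-fold lower number from compound 1 to compound 2 (0.13 log units; that floor lies within the scatter), the expected step of a 1.4-fold higher number from compound 2 to compound 3 (0.14 log units; within the scatter) is a modest move to higher numbers. Compound 3 is therefore estimated at 20000 nM, within 8000 nM to 50000 nM, and may only reach the limit (the limit of > 20000 nM in this assay, at which 1 of the 2 values shown sits).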

Compound 3, half-maximal effective concentration: > 20000 nM
Compound 3 gave a limit, no number; the forecaster's own chance of this, stated with the estimate: 50%; the middle value sits exactly at the limit.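

With anilino in place of piperidin-1-yl on a carbonyl carbon, this assay shows an at least 1.3-fold higher number from compound 2 to compound 3 (0.13 log units; that floor lies within the scatter). Compound 3 ends at a limit, so only that floor can be read, and the step between compound 1 and compound 3, which both end at limits, cannot be read at all. Of the three compounds, only compound 2, with its piperidin-1-yl amide, gives a number, while the two with an aryl group on the amide nitrogen do not: the limit of > 20000 nM in this assay, at which 2 of the 3 values shown sit.

From the compounds shown here alone, whether morpholin-4-yl or dimethylamino on the same carbonyl carbon would shift the number beyond the scatter stays open.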